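Clearance notes: swapping the group on the carbonyl carbon

A few compounds are considered here, and "the series" means these few. Any claim that something is new, unique, unknown or untested is made for them only; others in the source may bear on it.

compound 1 `Cc1ccc2[nH]c(C(=O)N[C@H]3CCN(S(=O)(=O)c4ccccc4Cl)C[C@@H]3C(=O)N[C@H]3CCCN(C)C3)cc2c1` at 244 mL.min-1.g-1
compound 2 `Cc1csc(C(=O)N[C@H]2CN(S(=O)(=O)c3ccccc3)C[C@@H]2C(=O)N[C@H]2CCCNC2)n1` at 9.1 mL.min-1.g-1

In an ADME assay on microsomes from liver (Homo sapiens) for metabolic stability (on this read-out higher numbers stand for fast clearance and lower numbers for slow clearance), compound 2 at 9.1 mL.min-1.g-1 stands lowest of the two measured compounds, beyond the scatter from compound 1. Compound 3 `O=C(N[C@H]1CN(S(=O)(=O)c2ccccc2)C[C@@H]1C(=O)N[C@H]1CCCNC1)c1cc(-c2ccccc2Cl)on1` differs from compound 2 as follows: a group of 12 heavy atoms (9 carbon, 1 nitrogen, 1 oxygen, 1 chlorine; one five-membered aromatic ring with 2 hetero atoms, one six-membered aromatic ring of carbon only) in place of a group of 6 heavy atoms (4 carbon, 1 nitrogen, 1 sulfur; one five-membered aromatic ring with 2 hetero atoms), on a carbonyl carbon on a carbonyl carbon. Going by the values given here, no measured step isolates this change. Among the compounds with values here, the only guide is compound 1 at 244 mL.min-1.g-1 on the high side, though it differs from compound 2 in more than one place. A rise beyond the scatter is expected, with an estimated step of a 4.4-fold higher number from compound 2 to compound 3 (0.64 log units; beyond the scatter) in this assay for now. For compound 3 the estimated value is 40 mL.min-1.g-1 with a range of 14 mL.min-1.g-1 to 120 mL.min-1.g-1 in this assay.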

Compound 3, intrinsic clearance in microsomes: < 3 mL.min-1.g-1
Compound 3 ended at the assay's limit; the forecaster's own chance of this, stated with the estimate: 3%; at least 13-fold (1.12 log units) between middle value and limit.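

Going by these compounds alone, this is the first step that isolates the group on the carbonyl carbon. In this assay, replacing 4-methyl-1,3-thiazol-2-yl with the 12-heavy-atom group bearing two aromatic rings gives an at least 3.0-fold lower number from compound 2 to compound 3 (0.48 log units; beyond the scatter), so at this position, in this pair, the larger group does not raise clearance. The value of compound 3 is a limit of the assay, not a number: the limit of < 3 mL.min-1.g-1 in this assay, at which 1 of the 3 values shown sits.

From the compounds shown here alone, the full size of the step remains open, as does which part of the entering group carries it. Also open, going by these compounds, is how a simple phenyl or an amine on the same carbonyl carbon would compare.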